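The compounds below may be only part of what the source reports. "The series", "measured", "known", "first", "only" and "open" are said of these compounds alone.

Measured in a functional assay on BT-549 cells (Homo sapiens) for antiproliferative activity, read by MTT assay, with a stated time of 48 h; on this read-out higher numbers stand for weaker inhibition and lower numbers for stronger inhibition:
- compound 1 `CN1C(=O)C(O)(Cc2nnn[nH]2)c2cc(F)ccc21` gives > 100000 nM, a limit
- compound 2 `O=C1N(Cc2ccc(Br)cc2)c2ccc(Cl)cc2C1(O)Cc1nnn[nH]1` gives 74500 nM
- compound 3 `CN1C(=O)C(O)(Cc2nnn[nH]2)c2cc(Br)ccc21` gives > 100000 nM, a limit

Compound 3 gives > 100000 nM in this assay, which is a limit and not a number, and it is one of the two compounds at the limit of > 100000 nM in this assay, at which 2 of the 3 values shown sit. Compound 4 `O=C1N(Cc2ccc(Br)cc2)c2ccc(Br)cc2C1(O)Cc1nnn[nH]1` follows from compound 3 through one change, (4-bromophenyl in place of hydrogen on a saturated chain carbon bound to an amide-type nitrogen in a ring), which can also be read as methyl to 4-bromobenzyl. Within the data shown here, the only measured step, a step that the two limits leave unreadable from compound 1 to compound 3, has no readable size and so offers none to carry over. The better guide is compound 2, which carries the same 4-bromobenzyl group and gives 74500 nM in this assay. On that basis, compound 4 is expected to show somewhat stronger inhibition than compound 3, though it may remain weak or reach the limit of the assay. The expected step, an at least 1.5-fold lower number from compound 3 to compound 4 (0.18 log units; that floor lies within the scatter), is an estimate and is modest in size. For compound 4 the estimated value is 65000 nM, with an expected range from 30000 nM to 100000 nM.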

Compound 4, half-maximal inhibitory concentration: 88800 nM
Beside the measured number, compound 4's estimate is 1.4-fold (0.14 log units) below it; the range from low to high includes it.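

In this assay, from the compounds shown here alone, methyl to 4-bromobenzyl at this position gives an at least 1.1-fold lower number from compound 3 to compound 4 (0.05 log units; that floor lies within the scatter), so the change brings a bromo compound to a readable value, but the true size of the step stays unknown. Compound 3 gives > 100000 nM, which is a limit and not a number: the limit of > 100000 nM in this assay, at which 2 of the 4 values shown sit. With the 4-bromobenzyl group in place, bromo in place of chloro on the aromatic carbon gives a 1.2-fold higher number from compound 2 to compound 4 (0.08 log units; within the scatter), whereas the fluoro-to-bromo step between the two methyl compounds cannot be read.

Going by these compounds, it remains open whether a plain benzyl, a longer chain or a chain ending in an amine at this place would give a value clearly beyond the scatter from compound 4. On these data alone, it is also open whether the 4-bromobenzyl group would give a readable value on the fluoro core of compound 1.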